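Selenocyanate in place of methylselenyl on the aryl ring

The compounds below may be only part of what the source reports. "The series", "measured", "known", "first", "only" and "open" are said of these compounds alone.

Measured so far:
compound 1, `C[Se]c1ccc(N(C)c2nc(C3CC3)nc3ccccc23)cc1`, 11 nM
compound 2, `COc1ccc(N(C)c2nc(C)nc3ccccc23)cc1OCCCCC[Se]C#N`, 5210 nM

The set rests on a functional assay on LoVo cells (Homo sapiens) for inhibition, read by MTT assay, with a stated time of 48 h; on this read-out lower numbers stand for stronger inhibition and higher numbers for weaker inhibition. Of the two measured compounds, compound 1 holds the lower number, and the gap to compound 2 lies well beyond the scatter of the assay, so on these numbers compound 1 is the stronger inhibitor. Going by the values given here, no single-point step connects the two measured compounds; they differ in several places at once, and only their two values can be compared.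

Compound 3, `CN(c1ccc([Se]C#N)cc1)c1nc(C2CC2)nc2ccccc12`, follows from compound 1 by one change: cyano in place of methyl on a selenium. The shared core and the remaining substituents are kept. Among the compounds with values here, no measured pair shows what this exchange on a selenium does, so the expectation rests on compound 1 alone.

A moderate weakening is expected, and the step from compound 1 to compound 3 is estimated at a 3.6-fold higher number from compound 1 to compound 3 (0.56 log units; beyond the scatter), small enough that the two numbers may still be close. Compound 3 is therefore expected to give about 40 nM in this assay, within a range of 10 nM to 200 nM.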

Compound 3, half-maximal inhibitory concentration: 11 nM
Beside the measured number, compound 3's estimate is 3.6-fold (0.56 log units) above it; the measured number falls inside the stated range.
By their numbers in this assay, from the lowest: compounds 1 and 3 (each within the scatter of the next); then compound 2.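

In this assay, the exchange of methyl for cyano on a selenium whose other neighbour is aromatic carbon gives no change at the digits printed from compound 1 to compound 3 (within the scatter). Going by these compounds alone, until this pair, the position had only the single value of compound 1 behind it; it now shows that the cyano group, with its triple bond and hydrogen-bond acceptor, can stand on this selenium and the value in this cell read-out stays within the scatter, so methyl is not required here for a number of this size. Nothing at hand explains why the two groups read alike.

From the compounds shown here alone, this is one pair on one core, so it remains open whether the exchange would read the same way with other substituents on the shared core, and compound 2 cannot settle that, as it differs from both in several places at once. Also open, going by these compounds, is what an ethyl or benzyl group on the selenium would do, or sulfur in place of selenium with methyl or cyano kept on it.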